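The compounds below may be only part of what the source reports. "The series", "measured", "known", "first", "only" and "open" are said of these compounds alone.

Measured in a functional assay on U-87MG ATCC cells (Homo sapiens) for cytotoxicity, read by resazurin assay, with a stated time of 48 h; on this read-out lower numbers stand for stronger inhibition and higher numbers for weaker inhibition:
- Compound 1 `O=C1/C(=C/c2ccc(O)cc2)CS(=O)(=O)C/C1=C\c1ccc([N+](=O)[O-])cc1`: 2170 nM
- Compound 2 `Cc1ccc(/C=C2\CS(=O)(=O)C/C(=C\c3ccc([N+](=O)[O-])cc3)C2=O)cc1`: 1390 nM
- Compound 3 `O=C1/C(=C/c2ccc([N+](=O)[O-])cc2)CCC/C1=C\c1ccc([N+](=O)[O-])cc1`: 27500 nM

Compound 3 has the highest number of the three at 27500 nM, which makes it the weakest inhibitor of this small set. The numbers of compound 1 and compound 2 both lie lower, and both gaps are beyond the usual scatter.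

The next compound, compound 4 `O=C1/C(=C/c2ccc([N+](=O)[O-])cc2)CC(O)C/C1=C\c1ccc([N+](=O)[O-])cc1`, differs from compound 3 in one place: hydroxy in place of hydrogen on a saturated ring carbon. In words, this is hydroxy in place of hydrogen on a saturated ring carbon.

For the measured compounds named here, only one measured step changes a single place: a 1.6-fold lower number from compound 1 to compound 2 (0.19 log units; within the scatter), with methyl in place of hydroxy on an aromatic carbon. That step lies within the scatter, but it offers only a weak guide, since it concerns an aromatic carbon and a core other than that of compound 3. Going by the values given here, no measured pair shows hydroxy arriving on a saturated ring carbon, so the data give no firm direction. In this assay, no step beyond the scatter is therefore expected.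

The expected change is a 1.1-fold lower number from compound 3 to compound 4 (0.06 log units; within the scatter), a small estimated step. For compound 4 the estimated value is 24000 nM, with an expected range from 9000 nM to 60000 nM.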

Compound 4, half-maximal inhibitory concentration: 4620 nM
Estimate against measurement, compound 4: 5.2-fold (0.72 log units) above; the whole stated range lies above it.
By their numbers in this assay, from the lowest: compounds 2 and 1 (each within the scatter of the next); then compound 4; then compound 3.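

In this assay placing a hydroxy on a saturated ring carbon of the six-membered carbon ring gives a 6.0-fold lower number from compound 3 to compound 4 (0.77 log units; beyond the scatter) and this step lies beyond the scatter. For the compounds shown here, it is the first sign that this position responds to a change: the swap of a hydrogen atom for a single oxygen-bearing group moves the number towards stronger inhibition, whereas the only earlier single-place step, on an aromatic carbon in a different core, stayed within the scatter. The data offer no explanation for why the hydroxy has this result here.

Hydroxy is the only group shown at this position, so it remains open whether the gain is particular to it or would also appear with another group on the same carbon, such as an amine, a methoxy or a carboxylic acid. Going by these compounds, it also remains open whether a hydroxy at this place would give a step of similar size and direction on a different core, such as the core of compound 1.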